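From thiophen-2-yl to cyclohexyl in compound 4

This account rests on a few compounds, and the source may have more. Where it says the series, first, only, none or still open, it means among the compounds named here.

In an ADME assay on microsomes from liver (Mus musculus) for metabolic stability, with a stated time of 15 min, tested at 1 uM (a higher number here means that more of the compound is left, a lower number that less of the compound is left), the measured compounds give:
Compound 1 `CC(C)c1cc(-c2nn(C(C)C)c3ncnc(N)c23)no1` gives 5.1%
Compound 2 `Cc1ccc(-c2cc(-c3nn(C(C)C)c(N)c3C(N)=O)no2)cc1` gives 61.8%
Compound 3 `CC(C)n1nc(-c2cc(-c3cccs3)on2)c(C(N)=O)c1N` gives 32.1%

Compound 3 holds the middle of these three numbers, with both gaps beyond the scatter. Compound 4 `CC(C)n1nc(-c2cc(C3CCCCC3)on2)c(C(N)=O)c1N` differs from it by one change (cyclohexyl in place of thiophen-2-yl on an aromatic carbon), cyclohexyl in place of thiophen-2-yl on an aromatic carbon. Among the measured compounds shown here, one measured step touches this place (a number 29.7 percentage points lower from compound 2 to compound 3 (beyond the scatter)), and it was modest. For the measured compounds named here, compound 1 has a different core and offers no clean step. Going by the values given here, no measured compound carries a non-aromatic ring here, so the direction is uncertain. A modest fall is nevertheless expected (a number 12.1 percentage points lower from compound 3 to compound 4 (beyond the scatter)) in this assay for this change. Compound 4 is estimated at 20% within an expected range from 5% to 45% in this read-out.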

Compound 4, percent of the compound remaining: 40.6%
Estimate against measurement, compound 4: 20.6 percentage points below; the range from low to high includes it.
By their numbers in this assay, from the lowest: compound 1; then compounds 3 and 4 (each within the scatter of the next); then compound 2.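

Putting cyclohexyl in place of thiophen-2-yl, next to the ring oxygen, leaves the two compounds indistinguishable (a number 8.5 percentage points higher from compound 3 to compound 4 (within the scatter)), so a non-aromatic carbon ring does as well here as a five-membered aromatic one. The 4-methylphenyl group still stands apart from cyclohexyl (a number 21.2 percentage points lower from compound 2 to compound 4 (beyond the scatter)), as it does from thiophen-2-yl (a number 29.7 percentage points lower from compound 2 to compound 3 (beyond the scatter)). No measurement available accounts for this order. Open, going by these compounds, is how a plain phenyl would compare, which would show whether the methyl group matters, and how an open chain such as n-butyl or a piperidine ring would fare at this position.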